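This account rests on a few compounds, and the source may have more. Where it says the series, first, only, none or still open, it means among the compounds named here.

Series notes. Compound 1 `CCC(=O)Oc1c(OC)c(OC)c(OC(=O)CC)c2ccccc12` carries two methoxy groups and two propanoyl esters on the shared core. Compound 3 `CCC(=O)Oc1c(OC)c(OC)c(OC(=O)CC)c2cc(Cl)ccc12` is compound 1 with chloro in place of hydrogen on an aromatic carbon. Compound 2 `CC(=O)Oc1c(Oc2ccccc2)c(Oc2ccccc2)c(OC(C)=O)c2ccccc12` carries two phenoxy groups and two acetyl esters on a core whose difference from that of compound 1 is not broken down here. Compound 4 `CC(=O)Oc1c(Oc2ccccc2)c(Oc2ccccc2)c(OC(C)=O)c2cc(Cl)ccc12` is compound 2 with the same change, chloro in place of hydrogen on an aromatic carbon.

In a physicochemical assay for lipophilicity (a lower number here means a more polar compound, a higher number a more lipophilic compound), compound 1 gives 3.44. Compound 3 gives 4.3, so a number 0.86 log units higher from compound 1 to compound 3 (beyond the scatter). Compound 2 gives 4.8, the highest of the three numbers, beyond the scatter against both compound 3 and compound 1.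

Among the measured compounds shown here, for compound 4 the step in this assay is expected to be a number 0.85 log units higher from compound 2 to compound 4 (beyond the scatter), because a number 0.86 log units higher from compound 1 to compound 3 (beyond the scatter) is the only measured step for the same change, chloro in place of hydrogen on an aromatic carbon, and it comes from this one pair alone. Compound 4 is therefore estimated at 5.65, with a range from 5.25 to 6.05 to allow for the different core and substituents of compound 2 and for the usual scatter of this assay.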

Compound 4, partition coefficient: 5.6
The estimate for compound 4 lay 0.05 log units above the measured number; the measured number falls inside the stated range.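

In this assay the new step, a number 0.80 log units higher from compound 2 to compound 4 (beyond the scatter), is close in size to the earlier one, a number 0.86 log units higher from compound 1 to compound 3 (beyond the scatter), so chloro in place of hydrogen on an aromatic carbon goes with a higher number of similar size on both cores, even though compound 1 and compound 2 carry different ether and ester groups. This shows that the step carried over between these two cores at this one place on the ring, but two pairs are a narrow base and do not establish a constant increment for the wider series, nor do they show which of the differing groups, if any, would alter the size of the step. Nothing available explains why the two steps are so alike, and no cause can be assigned to either of them.

The compounds shown leave open whether the step would hold on a core bearing an amine or a carboxylic acid in place of the propanoyl or acetyl esters, where the groups around the ring would differ far more than they do between these two cores. Also open, going by these compounds, are fluoro or bromo in place of chloro, and chloro at any other place on the ring.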